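The compounds below may be only part of what the source reports. "The series", "measured", "known", "first", "only" and "open" are said of these compounds alone.

Measured so far in an assay on isolated protein for inhibition of tyrosine-protein kinase receptor UFO (Homo sapiens), read by ELISA; on this read-out lower numbers stand for stronger inhibition and higher numbers for weaker inhibition:
compound 1 `Cn1cc(-c2ccc(NC(=O)c3cn(CC4CCOCC4)cc(-c4ccc(F)cc4F)c3=O)cc2)c2c(N)ncnc21` gives 0.8 nM
compound 2 `Cn1cc(-c2ccc(NC(=O)c3cn(CC4CCCCC4)cc(-c4ccc(F)cc4)c3=O)cc2)c2c(N)ncnc21` gives 2.3 nM
compound 3 `Cn1cc(-c2ccc(NC(=O)c3cn(CC4CCCO4)cc(-c4ccc(F)cc4)c3=O)cc2)c2c(N)ncnc21` gives 1.2 nM

The three numbers lie within the usual scatter of one another, and compound 3 sits in the middle of them: compound 1 reads a little lower and compound 2 a little higher, neither gap beyond the scatter. Among the measured compounds shown here, the only single-point step among the measured compounds is a 1.9-fold lower number from compound 2 to compound 3 (0.28 log units; within the scatter), which exchanges one saturated ring for another on a saturated chain carbon bound to an aromatic nitrogen without moving the number beyond the scatter.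

The next compound, compound 4 `CN(C)C(=O)Cn1cc(C(=O)Nc2ccc(-c3cn(C)c4ncnc(N)c34)cc2)c(=O)c(-c2ccc(F)cc2)c1`, has not yet been measured in this assay. It differs from compound 3 as follows: dimethylcarbamoyl in place of oxolan-2-yl on a saturated chain carbon bound to an aromatic nitrogen. The change sits at the same place as the step of a 1.9-fold lower number from compound 2 to compound 3 (0.28 log units; within the scatter), so that step is the one that bears on it, and it was small. For the measured compounds named here, no measured pair exchanges a ring for an open chain at this position, so the effect of losing the five-membered ring is untested; the only evidence is that this position has so far tolerated two different saturated groups. On that basis a step within the scatter is expected, with the range widened for the untested ring-to-chain exchange: compound 4 is estimated at 1.6 nM, between 0.5 nM and 5 nM, a step of a 1.3-fold higher number from compound 3 to compound 4 (0.12 log units; within the scatter).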

Compound 4, half-maximal inhibitory concentration: 0.5 nM
Estimate against measurement, compound 4: 3.2-fold (0.51 log units) above; measured number inside the range.
By their numbers in this assay, from the lowest: compounds 4, 1, 3 and 2 (each within the scatter of the next, the first and the last beyond it).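

In this assay the position on a saturated chain carbon bound to an aromatic nitrogen now shows a step beyond the scatter: dimethylcarbamoyl in place of oxolan-2-yl gives a 2.4-fold lower number from compound 3 to compound 4 (0.38 log units; beyond the scatter) and remains modest in size. Against the cyclohexyl group the same entering group gives a 4.6-fold lower number from compound 2 to compound 4 (0.66 log units; beyond the scatter) and so shows that a ring on this chain carbon is not needed for a low number among these three compounds, which share the rest of their structure. Oxolan-2-yl and dimethylcarbamoyl have the same heavy-atom and hydrogen-bond-acceptor counts, so those counts do not separate them, and no measurement here accounts for the step.

The compounds shown leave open which part of dimethylcarbamoyl carries the step, since neither an unsubstituted carboxamide nor a diethylamide appears among them, and a carboxylic acid, an amine or a longer chain at this place also remains unknown. Among the compounds shown here, they also leave open whether the step holds with the other aryl group on the core of compound 1, as no pair here tests dimethylcarbamoyl alongside it.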